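The compounds below may be only part of what the source reports. "The series", "measured", "known", "first", "only" and "open" are said of these compounds alone.

Compound 1, `O=C(Nc1ccc(S(=O)(=O)N2CCC3(CCCCC3)CC2)cc1)c1ccc([N+](=O)[O-])o1` — > 25000 nM
Compound 2, `CC1(C)CCN(S(=O)(=O)c2cccc(NC(=O)c3ccc([N+](=O)[O-])s3)c2)CC1` — > 25000 nM

Both measurements come from an ADME assay on IMR-90 cells (Homo sapiens) for cytotoxicity, read by CellTiter-Blue, with a stated time of 46 h; on this read-out higher numbers stand for an effect only at larger amounts of compound and lower numbers for an effect already at smaller amounts. For compound 1 the result is a limit of the assay, not a number, since it gives > 25000 nM. For compound 2 the result is likewise a limit rather than a number, as it gives > 25000 nM. Compound 2 therefore stands exactly where every other value shown stands: at the limit of > 25000 nM in this assay, at which 2 of the 2 values shown sit, so no ordering between the two measured compounds can be read from these results.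

Compound 3, `CC1(C)CCN(S(=O)(=O)c2cccc(NC(=O)c3ccc([N+](=O)[O-])o3)c2)CC1`, has not been measured. It differs from compound 2 in one place: 5-nitrofuran-2-yl in place of 5-nitrothiophen-2-yl on a carbonyl carbon. Compound 1 already carries the 5-nitrofuran-2-yl group on its carbonyl carbon and sits at the same limit as compound 2, although no single-step comparison between those two compounds exists. Nothing here points to a shift in either direction, so the expected step in this assay from compound 2 to compound 3 is none beyond the usual scatter, a step that the limit leaves unreadable from compound 2 to compound 3. Compound 3 is accordingly expected to give about 30000 nM, within a range of 15000 nM to 100000 nM, most likely reported again only as a limit.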

Compound 3, half-maximal effective concentration: > 25000 nM
Compound 3: a limit, no number; the forecaster's own chance of this, stated with the estimate: 85%; the middle value does not contradict the limit.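

No step can be read from compound 2 to compound 3, because both results are limits of the assay and not numbers: the limit of > 25000 nM in this assay, at which 3 of the 3 values shown sit.

The compounds shown leave open at what amount any of the three would show an effect in this assay and whether 5-nitrofuran-2-yl and 5-nitrothiophen-2-yl on a carbonyl carbon differ there at all.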